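Working notes: tert-butyl in place of trifluoromethyl

This account rests on a few compounds, and the source may have more. Where it says the series, first, only, none or still open, it means among the compounds named here.

Three measured compounds share one core and differ only in the aryl group on the aromatic nitrogen. Compound 1 `Cn1ncc2c(NC(=O)NCc3cc(C(F)(F)F)nn3-c3cccc(F)c3)cccc21` gives 7 nM in an assay on CHO-K1 cells for antagonist activity at transient receptor potential cation channel subfamily V member 1 (Homo sapiens), read by FLIPR and calcium flux, with a stated time of 6 min; on this read-out higher numbers stand for weaker inhibition and lower numbers for stronger inhibition. Compound 2 `Cn1ncc2c(NC(=O)NCc3cc(C(F)(F)F)nn3-c3cccc(C(F)(F)F)c3)cccc21` gives 1.4 nM in this assay, and compound 3 `Cn1ncc2c(NC(=O)NCc3cc(C(F)(F)F)nn3-c3ccc(F)cc3)cccc21` gives 8.4 nM. Compound 2 stands lowest of the three numbers: the steps are a 5.0-fold lower number from compound 1 to compound 2 (0.70 log units; beyond the scatter) and a 6.0-fold higher number from compound 2 to compound 3 (0.78 log units; beyond the scatter), both beyond the scatter, whereas a 1.2-fold higher number from compound 1 to compound 3 (0.08 log units; within the scatter) lies within it.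

Compound 4 `Cn1ncc2c(NC(=O)NCc3cc(C(C)(C)C)nn3-c3cccc(C(F)(F)F)c3)cccc21` has not been measured. It differs from compound 2 by tert-butyl in place of trifluoromethyl on an aromatic carbon. None of the three measured steps touches this place: each of them changes the group on the aromatic nitrogen, and the trifluoromethyl on the five-membered ring carbon is the same in compounds 1, 2 and 3. Among the compounds with values here, no measured step therefore bears on the change, and nothing in the numbers says which way the value in this assay should move. The expectation is a step within the scatter, with a wide range to cover the unsupported direction. Compound 4 is expected at 3 nM, between 0.8 nM and 12 nM, which means an estimated step of a 2.1-fold higher number from compound 2 to compound 4 (0.33 log units; beyond the scatter).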

Compound 4, inhibition constant: 0.6 nM
For compound 4 the middle estimate is 5.0-fold (0.70 log units) above the measured one, outside the stated range (below it).
By their numbers in this assay, from the lowest: compound 4; then compound 2; then compounds 1 and 3 (each within the scatter of the next).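

At the aromatic carbon next to the ring nitrogen, two ring bonds from the ring atom that bears the 3-(trifluoromethyl)phenyl group, this assay now gives a first reading: tert-butyl in place of trifluoromethyl produces a 2.3-fold lower number from compound 2 to compound 4 (0.37 log units; beyond the scatter). This carbon carries trifluoromethyl in compounds 1, 2 and 3, so those compounds could say nothing about it, whereas compound 4 shows that trifluoromethyl is not required here for a low number in this read-out, and that a group of 4 carbon atoms with no fluorine gives a lower number with the rest of compound 2 unchanged. Nothing shown explains why the number falls with this exchange of two groups of equal heavy-atom count, and the cause stays unassigned.

As far as these compounds go, the reading comes from a single pair carrying the 3-(trifluoromethyl)phenyl group, so it remains open whether the same exchange would give a step of similar size and direction with the 3-fluorophenyl of compound 1 or the 4-fluorophenyl of compound 3. Also open, from the compounds shown here alone, is how the number would respond at this carbon to other groups, such as methyl, cyclopropyl, a dimethylamino group or a longer chain like n-butyl.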